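Pyrazinyl Replaces Dimethoxyphenyl on the Ring Nitrogen

The source may hold more compounds than are shown below. What is called first, only, known or untested is meant among the compounds shown, and "the series" means these compounds.

In a functional assay on HOS-TE85 cells (Homo sapiens) for inhibition, read by CCK-8 assay, with a stated time of 72 h (on this read-out lower numbers stand for stronger inhibition and higher numbers for weaker inhibition), compound 1 `CC1SC(c2cccc(C(=O)NCCCCc3ccccc3)c2)N(c2ccc(C3CC3)cc2)C1=O` gives 191 nM, and compound 2 `CCOC(=O)c1sc(N2C(=O)CSC2c2cccc(C(=O)NCCCCn3cccn3)c2)nc1C` gives 430 nM. Compound 3 `COc1cccc(OC)c1N1C(=O)CSC1c1cccc(C(=O)NCCCCc2ccccc2)c1` returns only a limit in this assay, > 1000 nM, so its place is at the limit of > 1000 nM in this assay, at which 1 of the 3 values shown sits, rather than at a number. Compound 4 `O=C(NCCCCc1ccccc1)c1cccc(C2SCC(=O)N2c2cnccn2)c1` differs from compound 3 in one place: pyrazin-2-yl in place of 2,6-dimethoxyphenyl on an amide-type nitrogen in a ring. Among the compounds with values here, no measured pair with a single change is at hand, so the size of this step rests on the three values shown. Compound 1 and compound 2 show that the shared core can reach numbers well under the limit, and compound 4 is expected to move in that direction, with the step from compound 3 to compound 4 estimated at an at least 1.6-fold lower number from compound 3 to compound 4 (0.22 log units; that floor lies within the scatter). Compound 4 is expected to give about 600 nM, within 150 nM to 2500 nM.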

Compound 4, half-maximal inhibitory concentration: > 1000 nM
Compound 4 was reported as a limit; the forecaster's own chance of this, stated with the estimate: 35%; middle value at least 1.6-fold (0.22 log units) away from the limit.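

In this assay compound 3 and compound 4 are both reported as limits, so no step between them can be read: the limit of > 1000 nM in this assay, at which 2 of the 4 values shown sit.

In this assay the compounds shown leave open whether pyrazin-2-yl and 2,6-dimethoxyphenyl differ at all.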